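Notes on the step from compound 2 to compound 4

This account rests on a few compounds, and the source may have more. Where it says the series, first, only, none or still open, it means among the compounds named here.

In a functional assay on K562 cells (Homo sapiens) for inhibition, read by trypan blue exclusion, with a stated time of 72 h (a higher number here means a weaker inhibitor, a lower number a stronger inhibitor), compound 2 `Cc1ccc(S(=O)(=O)c2cc3cnc(Nc4cnc5c(c4)CC(=O)N5)nc3n(C)c2=O)cc1` gives 15000 nM. Compound 3 `Cn1c(=O)c(S(=O)(=O)c2ccccc2)cc2cnc(Nc3ccc4cc[nH]c4c3)nc21` gives 10000 nM, which lies within the scatter of the value for compound 2. Compound 1 `Cn1c(=O)c(S(=O)(=O)c2ccc(F)cc2F)cc2cnc(Nc3cccc4[nH]ccc34)nc21` gives 1500 nM, and its gap to compound 2 lies beyond the scatter. Compound 2 therefore shares the high end of the numbers with compound 3, while compound 1 sits clearly lower.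

Compound 4 `Cc1ccc(S(=O)(=O)c2cc3cnc(Nc4ccc5ncccc5c4)nc3n(C)c2=O)cc1` is the next analogue of compound 2, with the change made on a nitrogen on an aromatic ring: a group of 10 heavy atoms (9 carbon, 1 nitrogen; one six-membered aromatic ring of carbon only, one six-membered aromatic ring with 1 hetero atom) in place of a group of 10 heavy atoms (7 carbon, 2 nitrogen, 1 oxygen; one five-membered non-aromatic ring with 1 hetero atom, one six-membered aromatic ring with 1 hetero atom), on a nitrogen on an aromatic ring. Quinolin-6-yl is the group that enters. Among the compounds with values here, no measured pair isolates this change, as compound 1 and compound 3 each differ from compound 2 in more than one place. The evidence is thus indirect. Compound 1, at 1500 nM, shows that a different group in this place can go with a lower number. Compound 3, at 10000 nM, shows that it need not.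

A moderate move towards a lower number is expected, with the estimated step being a 3.0-fold lower number from compound 2 to compound 4 (0.48 log units; beyond the scatter). The range also allows for no real change. For compound 4 the estimated value in this assay is 5000 nM, with an expected range of 1500 nM to 15000 nM.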

Compound 4, half-maximal inhibitory concentration: 10000 nM
Estimate against measurement, compound 4: 2.0-fold (0.30 log units) below; low and high end bracket the measured number.
By their numbers in this assay, from the lowest: compound 1; then compounds 3, 4 and 2 (each within the scatter of the next).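

In this assay, within the data shown here, quinolin-6-yl in place of the leaving group on the nitrogen gives a 1.5-fold lower number from compound 2 to compound 4 (0.18 log units; within the scatter) and so provides the first pair that isolates this position. At this level of the read-out, the position tolerates the exchange of a group holding a five-membered non-aromatic ring, 1 hydrogen-bond donor and 2 hydrogen-bond acceptors for an all-aromatic group with 0 hydrogen-bond donors and 1 hydrogen-bond acceptor, with no change that can be told from scatter, so none of these listed differences is shown to matter in this pair. Nothing measured here explains why the two values cannot be separated.

On these data alone, it remains open whether a substituent on quinolin-6-yl, such as a piperazine, a carboxylic acid or a longer chain carrying an amine, would give a step beyond the scatter at this position. The compounds shown also leave open whether the same exchange would give a similar step on the core of compound 1 or the core of compound 3, since only one pair isolates it.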